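Dichlorophenyl in Place of Phenyl in an Antiproliferative Series

This account rests on a few compounds, and the source may have more. Where it says the series, first, only, none or still open, it means among the compounds named here.

Compound 1 `Cc1nc(-c2ccccc2)sc1C(=O)CSc1nc(-c2ccccc2)c(C#N)c(=O)[nH]1` gives 87.5%; compound 3 `Cc1nc(-c2ccc(Cl)cc2)sc1C(=O)CSc1nc(-c2ccccc2)c(C#N)c(=O)[nH]1` gives 83.1%; compound 2 `Cc1nc(-c2ccccc2)sc1C(=O)CSc1nc(N)c(C#N)c(-c2ccc(Cl)cc2)n1` gives 58.8%.

Measured in a functional assay on U-87MG ATCC cells for antiproliferative activity against U-87 MG (Homo sapiens), read by MTT assay, with a stated time of 48 h, tested at 10 uM (on this read-out lower numbers stand for a stronger effect and higher numbers for a weaker effect at the one concentration tested), compound 1 stands at the top of the three numbers, though its nearest neighbour, compound 3, sits close by: the step of a number 4.4 percentage points lower from compound 1 to compound 3 (within the scatter) is within the scatter, so the two cannot be ranked. Compound 2 lies further off, and its value and that of compound 1 differ beyond the scatter.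

The unmeasured compound 4 `Cc1nc(-c2ccccc2)sc1C(=O)CSc1nc(-c2ccc(Cl)c(Cl)c2)c(C#N)c(=O)[nH]1` is reached from compound 1 by 3,4-dichlorophenyl in place of phenyl on an aromatic carbon. Within the data shown here, the only measured step that resembles this change is the one from compound 1 to compound 3, where chloro replaced hydrogen on an aromatic carbon and the read-out moved by a number 4.4 percentage points lower from compound 1 to compound 3 (within the scatter), within the scatter. On that basis the step of a number 7.5 percentage points lower from compound 1 to compound 4 (within the scatter) is expected to stay within the scatter, perhaps leaning slightly lower. Compound 4 is therefore estimated at 80%, with a range from 62% to 95%.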

Compound 4, a percentage reported as activity, at one concentration (the size of the read-out at that concentration, not a potency): 92.5%
Estimate against measurement, compound 4: 12.5 percentage points below; the measured number falls inside the stated range.
By their numbers in this assay, from the lowest: compound 2; then compounds 3, 1 and 4 (each within the scatter of the next).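

Among the compounds shown, only compound 4 carries a change at the phenyl next to the ring nitrogen and ortho to a cyano group, whereas the chloro of compound 3 lies on the other phenyl. In this assay, 3,4-dichlorophenyl in place of phenyl at this position gives a number 5 percentage points higher from compound 1 to compound 4 (within the scatter), so this exchange produces no readable change in the read-out. No measurement shown here offers an explanation for this result.

On these data alone, whether a morpholine or a carboxylic acid in place of the phenyl at this position would move the number beyond the scatter remains open. As far as these compounds go, it is also open whether a single chloro on this phenyl would read like 3,4-dichlorophenyl, and whether any group here could bring the number down.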